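Bicyclic amide replacement in the sulfone-benzylamide series

The source may hold more compounds than are shown below. What is called first, only, known or untested is meant among the compounds shown, and "the series" means these compounds.

Compound 2 `O=C(NCc1ccc(S(=O)(=O)c2ccccc2)cc1)c1cc2ncccc2s1` stands at the top of the two numbers measured in an assay for inhibition of Nicotinamide phosphoribosyltransferase (Homo sapiens), read by mass spectrometry, with stated times of 15 min and 30 min; a higher number here means a weaker inhibitor, a lower number a stronger inhibitor: compound 2 gives 400 nM. Compound 1 `O=C(NCc1ccc(S(=O)(=O)c2ccccc2)cc1)c1cc2ccncc2s1` shares the whole sulfone-benzylamide part and differs only in the bicyclic group on the carbonyl carbon; in this assay compound 1 gives 7 nM, and the step of a 57-fold higher number from compound 1 to compound 2 (1.76 log units; beyond the scatter) shows that exchanging one bicyclic group for another at this position can move the number far beyond the scatter.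

Compound 3 `O=C(NCc1ccc(S(=O)(=O)c2ccccc2)cc1)c1cn2ccnc2cn1` carries the change (a group of 9 heavy atoms (6 carbon, 3 nitrogen; one five-membered aromatic ring with 2 hetero atoms, one six-membered aromatic ring with 2 hetero atoms) in place of a group of 9 heavy atoms (7 carbon, 1 nitrogen, 1 sulfur; one five-membered aromatic ring with 1 hetero atom, one six-membered aromatic ring with 1 hetero atom), on a carbonyl carbon). Among the measured compounds shown here, the only measured step that bears on it is the one from compound 1 to compound 2, which was large; it tells that the bicyclic group matters strongly but gives no direction for a group with more nitrogen and no sulfur. A step of comparable size is therefore expected in this assay for compound 3, with the direction uncertain and a wide range allowed. The estimate for compound 3 is 100 nM, in the range 8 nM to 1500 nM, corresponding to an expected step of a 4.0-fold lower number from compound 2 to compound 3 (0.60 log units; beyond the scatter).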

Compound 3, half-maximal inhibitory concentration: 150 nM
Compound 3: middle estimate off by 1.5-fold (0.18 log units), on the low side; measured number inside the range.
By their numbers in this assay, from the lowest: compound 1; then compound 3; then compound 2.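

Across the three bicyclic groups on the carbonyl carbon, the group with 6 carbon and 3 nitrogen atoms falls between the two groups that hold sulfur in this assay: the step of a 2.7-fold lower number from compound 2 to compound 3 (0.43 log units; beyond the scatter) is modest though beyond the scatter, whereas the step of a 21-fold higher number from compound 1 to compound 3 (1.33 log units; beyond the scatter) remains large. The presence of sulfur in the group therefore does not by itself set the number at this position, as the two sulfur-containing groups lie on opposite sides of the sulfur-free one, and a group with no sulfur and an added hydrogen-bond acceptor still gives a lower number than the sulfur-containing group of compound 2. No measurement on these compounds accounts for the order of the three groups.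

The change to compound 3 alters the atoms of both rings at once, so the contributions of losing sulfur and of adding nitrogen cannot be separated from these data. Also open, going by these compounds, is how far the number would move with a longer chain carrying an amine in place of the bicyclic group on the carbonyl carbon, since all three compounds keep a fused pair of aromatic rings there.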